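A few compounds are considered here, and "the series" means these few. Any claim that something is new, unique, unknown or untested is made for them only; others in the source may bear on it.

Series notes. In a physicochemical assay for solubility, read by HPLC, with a stated time of 24 h (a lower number here means a less soluble compound, a higher number a more soluble compound), compound 1 `O=C1O[C@@H](CN2CCCCC2)CN1c1ccc(-n2cc(-c3ccccn3)cn2)c(F)c1` gives 219000 nM. Compound 2 `O=C1O[C@@H](CN2CCC(c3ccc(F)cc3)CC2)CN1c1ccc(-n2cc(-c3ccccn3)cn2)c(F)c1` reaches only a limit of this assay, <= 19400 nM. Compound 3 `O=C(OC[C@H]1CN(c2ccc(-n3cc(-c4ccccn4)cn3)c(F)c2)C(=O)O1)c1ccccc1` likewise reaches only a limit in this assay, <= 65400 nM, so its standing among the three values is known only as a ceiling, and two of those three values are limits (the limit of <= 19400 nM in this assay, at which 1 of the 3 values shown sits, (the limit of <= 65400 nM in this assay, at which 1 of the 3 values shown sits)). The measured steps are an at least 11-fold lower number from compound 1 to compound 2 (1.05 log units; beyond the scatter) and an at least 3.3-fold lower number from compound 1 to compound 3 (0.52 log units; beyond the scatter). Compound 4 `CCNC(=O)NC[C@H]1CN(c2ccc(-n3cc(-c4ccccn4)cn3)c(F)c2)C(=O)O1` differs from compound 3 by (ethylcarbamoyl)amino in place of benzoyloxy on a saturated chain carbon bound to a saturated ring carbon. Neither step covers this change directly; both ran downward, and compound 4 gives up the six-membered aromatic ring, so an upward step is expected, an at least 2.2-fold higher number from compound 3 to compound 4 (0.36 log units; beyond the scatter), its size uncertain against a ceiling. Compound 4 is estimated at 150000 nM, between 40000 nM and 450000 nM.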

Compound 4, solubility: 222000 nM
Estimate against measurement, compound 4: 1.5-fold (0.17 log units) below; the measured number falls inside the stated range.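

At this saturated chain carbon bound to a saturated ring carbon, (ethylcarbamoyl)amino in place of benzoyloxy gives an upward step in this assay (an at least 3.3-fold higher number from compound 3 to compound 4 (0.53 log units; beyond the scatter)), its size resting on a limit for compound 3. In place of piperidin-1-yl, the same group gives no change beyond the scatter (a 1.0-fold higher number from compound 1 to compound 4 (0.01 log units; within the scatter)), so a group with no ring holds the level of compound 1. No measured property shown here accounts for either step.

As far as these compounds go, whether the upward step follows the loss of the six-membered aromatic ring or the entry of the two hydrogen-bond donors stays open. From the compounds shown here alone, how a carboxylic acid or a primary amine at this place would read also remains open.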